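The source may hold more compounds than are shown below. What is called first, only, known or untested is meant among the compounds shown, and "the series" means these compounds.

Measured compounds in an in vitro assay on BHK cells for displacement of a labelled ligand from Glucagon receptor (Homo sapiens), read by scintillation proximity assay; on this read-out lower numbers stand for stronger inhibition and higher numbers for weaker inhibition:
compound 1 `Cc1cc(N(Cc2ccc(C(=O)NCCC(=O)O)cc2)c2nc(-c3ccc(C(F)(F)F)cc3)cs2)ccc1C(C)C`: 119 nM
compound 2 `O=C(O)CCNC(=O)c1ccc(CN(c2ccc3c(c2)CCC3)c2nc(-c3ccc(C(F)(F)F)cc3)cs2)cc1`: 86 nM

Within the data shown here, compound 2 holds the lower of the two numbers in this assay, yet the only step leading to it, a 1.4-fold lower number from compound 1 to compound 2 (0.14 log units; within the scatter), lies within the scatter, so the two compounds are not separated. Among the measured compounds shown here, that step, 2,3-dihydro-1H-inden-5-yl in place of 4-isopropyl-3-methylphenyl on a nitrogen on an aromatic ring, is the only measured change at this position. Compound 3 `O=C(O)CCNC(=O)c1ccc(CN(c2ccc(OC(F)(F)F)cc2)c2nc(-c3ccc(C(F)(F)F)cc3)cs2)cc1` carries the change (4-(trifluoromethoxy)phenyl in place of 2,3-dihydro-1H-inden-5-yl on a nitrogen on an aromatic ring), again an exchange of the aryl group on the same nitrogen. For the measured compounds named here, the one measured step at this site, a 1.4-fold lower number from compound 1 to compound 2 (0.14 log units; within the scatter), stayed within the scatter, and nothing measured points to a larger effect for a different aryl group here. Compound 3 is therefore expected to show a 1.2-fold higher number from compound 2 to compound 3 (0.07 log units; within the scatter) in this assay, a step not beyond the scatter. The estimated value of compound 3 is 100 nM, with a range from 40 nM to 250 nM.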

Compound 3, half-maximal inhibitory concentration: 92 nM
For compound 3 the middle estimate is 1.1-fold (0.04 log units) above the measured one; the measured number falls inside the stated range.
By their numbers in this assay, from the lowest: compounds 2, 3 and 1 (each within the scatter of the next).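

In this assay, 4-(trifluoromethoxy)phenyl in place of the all-carbon 2,3-dihydro-1H-inden-5-yl gives a 1.1-fold higher number from compound 2 to compound 3 (0.03 log units; within the scatter), and in place of 4-isopropyl-3-methylphenyl it gives a 1.3-fold lower number from compound 1 to compound 3 (0.11 log units; within the scatter). The earlier pair compared only all-carbon aryl groups on this nitrogen; an aryl group carrying oxygen and fluorine now leaves the number unseparated from both, so all three compounds stand level within the scatter. No available evidence bears on this result.

Still open, going by these compounds, is whether an aryl group on this nitrogen bearing an amine or a carboxylic acid would move the number beyond the scatter. On these data alone, all three compounds share the rest of the structure, so whether this level result would persist with a tetrazole in place of the carboxylic acid is also open.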